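A few compounds are considered here, and "the series" means these few. Any claim that something is new, unique, unknown or untested is made for them only; others in the source may bear on it.

Measured compounds in an ADME assay on microsomes from liver (Rattus norvegicus) for metabolic stability, using NADPH, with a stated time of 10 min; a higher number here means that more of the compound is left, a lower number that less of the compound is left:
compound 1 `CCCCc1nc(=O)c(S(=O)(=O)c2ccc(-c3cccnc3)cc2)c(O)n1-c1c(OC)cccc1OC`: 3%
compound 2 `CCCCc1nc(=O)c(S(=O)(=O)c2ccc(-n3cc(Cl)ccc3=O)cc2)c(O)n1-c1c(OC)cccc1OC`: 74%
compound 3 `CCCCc1[nH]c(=O)c(S(=O)(=O)c2ccc(-c3ccncc3C)cc2)c(O)c1-c1c(OC)cccc1OC`: 57%

Compound 3 stands second highest of the three numbers: compound 2 lies above it, beyond the scatter, and compound 1 lies far below it, also beyond the scatter. Compound 4 `CCCCc1[nH]c(=O)c(S(=O)(=O)c2ccc(-n3ccccc3=O)cc2)c(O)c1-c1c(OC)cccc1OC` is not yet measured. It differs from compound 3 in one place: a group of 7 heavy atoms (5 carbon, 1 nitrogen, 1 oxygen; one six-membered aromatic ring with 1 hetero atom) in place of a group of 7 heavy atoms (6 carbon, 1 nitrogen; one six-membered aromatic ring with 1 hetero atom), on an aromatic carbon. Among the measured compounds shown here, the one measured step that bears on this exchange is a number 71 percentage points higher from compound 1 to compound 2 (beyond the scatter), an exchange of the same kind, though there the entering ring carried a chlorine and the core was that of compound 1. Compound 3 already starts at 57%, so the room above it is smaller. An upward step is expected, a number 21 percentage points higher from compound 3 to compound 4 (beyond the scatter). Compound 4 is estimated at 78%, with a range from 60% to 92%.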

Compound 4, percent of the compound remaining: 100%
The estimate for compound 4 lay 22 percentage points below the measured number; the measured number lies above the stated range.
By their numbers in this assay, from the lowest: compound 1; then compound 3; then compound 2; then compound 4.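

In this assay, at this place on an aromatic carbon para to a large group, replacing 3-methylpyridin-4-yl with the entering ring gives a number 43 percentage points higher from compound 3 to compound 4 (beyond the scatter) on the core of compound 3. The upward direction of a number 71 percentage points higher from compound 1 to compound 2 (beyond the scatter) therefore recurs on a second core, here with no chlorine on the entering ring and with the same count of heavy atoms in both groups. Nothing available explains the size of either step.

Still open, on these data alone, is what a chlorine on the entering ring would do on the core of compound 3. Also open, as far as these compounds go, is how a morpholine or a carboxylic acid at this place would compare.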